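The source may report more compounds than this note shows. Statements on the series, on what has been measured and on what is new or still open speak of the compounds shown alone.

Series notes. Compound 3 `CCC(CC)c1ccc2c(NCCCNCc3ccco3)ccnc2c1` in an ADME assay for permeability, using PAMPA, with a stated time of 30 min, at pH 7.4 (on this read-out higher numbers stand for higher permeability and lower numbers for lower permeability), gives 23 10^-6 cm/s. Compound 2 `Cc1cc(C)cc(Cc2ccc3c(NCCCNCc4ccco4)ccnc3c2)c1` in this assay gives 23 10^-6 cm/s, and no change at the digits printed from compound 2 to compound 3 (within the scatter). Compound 1 `Fc1ccc(-c2ccc3c(NCCCNCc4ccco4)ccnc3c2)cc1` in this assay gives 237 10^-6 cm/s; compound 3 therefore shares the lowest number of the three with compound 2, with compound 2 nearest and compound 1 furthest away.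

Compound 4 `COc1ccccc1Oc1ccc2c(NCCCNCc3ccco3)ccnc2c1` is not yet measured. It differs from compound 3 by 2-methoxyphenoxy in place of pentan-3-yl on an aromatic carbon. The measured steps at this position are a 10-fold lower number from compound 1 to compound 3 (1.01 log units; beyond the scatter), a 10-fold lower number from compound 1 to compound 2 (1.01 log units; beyond the scatter) and no change at the digits printed from compound 2 to compound 3 (within the scatter). Compound 1, carrying 4-fluorophenyl at this position, stands apart from the two other substituents, which sit level with each other. Within the data shown here, a 2-methoxyphenoxy group at this position has no measured precedent, so the size of the coming step is open.

Because a 10-fold lower number from compound 1 to compound 3 (1.01 log units; beyond the scatter) shows how far a change at this position can move the number, compound 4 is expected to show a 2.6-fold higher number from compound 3 to compound 4 (0.42 log units; beyond the scatter). The expected value for compound 4 is 60 10^-6 cm/s, with a range from 15 10^-6 cm/s to 240 10^-6 cm/s.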

Compound 4, apparent permeability: 317 10^-6 cm/s
The estimate for compound 4 lay 5.3-fold (0.72 log units) below the measured number, outside the stated range (above it).
By their numbers in this assay, from the lowest: compounds 2 and 3 (each within the scatter of the next); then compounds 1 and 4 (each within the scatter of the next).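

Working notes. The 2-methoxyphenoxy group shows that the high end of this assay at this position is not particular to 4-fluorophenyl: there is a 1.3-fold higher number from compound 1 to compound 4 (0.13 log units; within the scatter) and so no separation between these two groups. The replacement of the low-lying groups moves the number a long way, with a 14-fold higher number from compound 3 to compound 4 (1.14 log units; beyond the scatter) and, by the same measure, a 14-fold higher number from compound 2 to compound 4 (1.14 log units; beyond the scatter) (the two low groups being level, the change holds against either one). A six-membered aromatic ring in the substituent does not by itself sort the series, as compound 4 and compound 1 stand high while compound 2, whose 3,5-dimethylbenzyl group also carries such a ring, stands low with the ringless pentan-3-yl of compound 3.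

No measurement here bears on why the number moves at this position. As far as these compounds go, with only four groups compared on the shared core, it stays open how an amine, a carboxylic acid or a longer carbon chain at this aromatic carbon would fall relative to these two levels. Also open, from the compounds shown here alone, is whether a plain phenoxy group, without the methoxy, would stay with compound 4 at the high level.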